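Chain lengthening between the ring nitrogen and the sulfamoyl group

This account rests on a few compounds, and the source may have more. Where it says the series, first, only, none or still open, it means among the compounds named here.

Three analogues with the shared core of compound 1 `CS(=O)(=O)NNc1nonc1/C(=N/O)Nc1ccc(F)c(Br)c1` have been measured in an assay on isolated protein for inhibition of Indoleamine 2,3-dioxygenase 1 (Homo sapiens), read by fluorescence, with a stated time of 60 min; on this read-out lower numbers stand for stronger inhibition and higher numbers for weaker inhibition. Compound 1 gives 609 nM. Compound 2 `NS(=O)(=O)CCNc1nonc1/C(=N/O)Nc1ccc(F)c(Br)c1` gives 71 nM in this assay, and compound 3 `O=S(=O)(CCNc1nonc1/C(=N/O)Nc1ccc(F)c(Br)c1)NO` gives 126 nM. Compound 2 holds the lowest number of the three: the step of an 8.6-fold lower number from compound 1 to compound 2 (0.93 log units; beyond the scatter) lies beyond the scatter, as does a 4.8-fold lower number from compound 1 to compound 3 (0.68 log units; beyond the scatter), whereas a 1.8-fold higher number from compound 2 to compound 3 (0.25 log units; within the scatter) stays within it, so compound 2 and compound 3 cannot be set apart on these data.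

Compound 4 `NS(=O)(=O)CCCNc1nonc1/C(=N/O)Nc1ccc(F)c(Br)c1` has not yet been measured. The change from compound 2 is sulfamoylmethyl in place of sulfamoyl on a saturated chain carbon, two bonds along the chain from a nitrogen on an aromatic ring; in short, sulfamoylmethyl in place of sulfamoyl on a saturated chain carbon, two bonds along the chain from a nitrogen on an aromatic ring. Among the measured compounds shown here, no measured step touches chain length between the ring nitrogen and the sulfamoyl group. The steps from compound 1 exchange the whole side arm, and the step of a 1.8-fold higher number from compound 2 to compound 3 (0.25 log units; within the scatter) changes only the sulfonamide nitrogen. The nearest guidance is that the two-carbon arm of compound 2 and compound 3 both keep low numbers. The step from compound 2 to compound 4 is therefore expected to be small, a 1.4-fold higher number from compound 2 to compound 4 (0.15 log units; within the scatter), with no clear direction beyond the scatter. Compound 4 is estimated at 100 nM in this assay, expected between 40 nM and 250 nM.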

Compound 4, half-maximal inhibitory concentration: 126 nM
Beside the measured number, compound 4's estimate is 1.3-fold (0.10 log units) below it, within the range that was stated.
By their numbers in this assay, from the lowest: compounds 2, 3 and 4 (each within the scatter of the next); then compound 1.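

In this assay, among the compounds shown here, the change from 2-sulfamoylethyl to 3-sulfamoylpropyl on a nitrogen on an aromatic ring gives a 1.8-fold higher number from compound 2 to compound 4 (0.25 log units; within the scatter), the first direct reading of chain length, and on these data the extra chain carbon cannot be told apart from no effect. The 3-sulfamoylpropyl arm also cannot be separated from the 2-(hydroxysulfamoyl)ethyl arm, with no change at the digits printed from compound 3 to compound 4 (within the scatter), while a 4.8-fold lower number from compound 1 to compound 4 (0.68 log units; beyond the scatter) shows that both sulfamoyl chain lengths, not just one, stand beyond the scatter from the methanesulfonamido arm. No measurement shown here bears on why the two chain lengths read alike.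

Going by these compounds, whether this flat reading holds for a longer chain carrying sulfamoyl, or for sulfamoylmethyl directly on a nitrogen on an aromatic ring, remains open, so the limits of the usable chain length are unknown. Also open, on these data alone, is whether a carboxylic acid or a primary amide in place of sulfamoyl on a saturated chain carbon would stay in the same range as the 3-sulfamoylpropyl arm.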